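Trifluoromethyl for chloro on the benzyl ring

A few compounds are considered here, and "the series" means these few. Any claim that something is new, unique, unknown or untested is made for them only; others in the source may bear on it.

Measured so far:
compound 1, `O=C(NC1CCN(Cc2ccc(Br)cc2)CC1)c1cccc2ccccc12`, 44 nM
compound 2, `O=C(NC1CCN(Cc2ccc(Cl)cc2)CC1)c1ccc2ccccc2c1`, 37 nM

Of the compounds shown here, two have been measured in an assay on isolated protein for displacement of a labelled ligand from D(4) dopamine receptor (Homo sapiens); on this read-out higher numbers stand for weaker inhibition and lower numbers for stronger inhibition. Compound 1 gives 44 nM and compound 2 gives 37 nM. Compound 2 shows the lowest of the two numbers, but its nearest neighbour, compound 1, lies within the scatter of repeated measurements, so the two values cannot be told apart. Within the data shown here, compounds 1 and 2 differ in more than one place, and no single step between them can be read off.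

The next compound, compound 3, `O=C(NC1CCN(Cc2ccc(C(F)(F)F)cc2)CC1)c1ccc2ccccc2c1`, differs from compound 2 in one place: trifluoromethyl in place of chloro on an aromatic carbon. The change sits on an aromatic carbon of a six-membered aromatic ring of carbon only, para to a large group, and cut one bond further out it reads 4-chlorophenyl to 4-(trifluoromethyl)phenyl. Among the measured compounds shown here, no measured pair isolates such a change, so no step size can be taken from the data. The expectation is a step in this assay from compound 2 to compound 3 of a 1.5-fold higher number from compound 2 to compound 3 (0.17 log units; within the scatter), that is, none beyond the scatter, with a slight lean toward a higher number. For compound 3 the estimate is 55 nM, with a range from 15 nM to 200 nM.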

Compound 3, inhibition constant: 84 nM
Estimate against measurement, compound 3: 1.5-fold (0.18 log units) below; the range from low to high includes it.
By their numbers in this assay, from the lowest: compounds 2, 1 and 3 (each within the scatter of the next, the first and the last beyond it).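

Among these compounds, this is the first step that isolates a single place: in this assay, trifluoromethyl in place of chloro on an aromatic carbon, para to a large group, gives a 2.3-fold higher number from compound 2 to compound 3 (0.36 log units; beyond the scatter), a modest change but one that lies beyond the scatter. Among the compounds shown here, the substituent at this place therefore registers on this read-out, which compounds 1 and 2 could not show, as they differ in more than one place and give no single step. The step rests on one pair and gives only a direction for this one exchange, with a heavier group of four atoms entering where a single chlorine leaves, and nothing in the data available here accounts for its size or direction.

Still open, as far as these compounds go, is how other groups at this place would read on the same scale, such as a nitrile, a methoxy group, a primary amine or a carboxylic acid, and whether the order of chloro and trifluoromethyl would extend to them. Also open, from the compounds shown here alone, is whether the same exchange carried out on the core of compound 1 would give a step of similar size and direction, or whether this result holds only for the core shared by compound 2 and compound 3.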